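Amide Substituent Change on a Bis-sulfonyl Piperidine Core

This account rests on a few compounds, and the source may have more. Where it says the series, first, only, none or still open, it means among the compounds named here.

The measured compounds and their values:
Compound 1, `CCN(CC)S(=O)(=O)c1ccc(S(=O)(=O)N2CCC[C@@H](C(=O)N[C@H]3CC[C@H](OC)CC3)C2)cc1`: 2000 nM
Compound 2, `CC(C)CS(=O)(=O)c1ccc(S(=O)(=O)N2CCC[C@@H](C(=O)N3CCC(F)(F)CC3)C2)cc1`: 311 nM
Compound 3, `O=C([C@@H]1CCCN(S(=O)(=O)c2ccc(S(=O)(=O)C3COC3)cc2)C1)N1CCC(F)(F)CC1`: 361 nM

All three were tested in a functional assay on BXPC-3 cells (Homo sapiens) for inhibition, read by MTT assay, with a stated time of 7 days; on this read-out lower numbers stand for stronger inhibition and higher numbers for weaker inhibition. Compound 1 gives the highest number of the three, so it stands as the weakest inhibitor in this set; compound 3 lies nearest to it and compound 2 furthest, both well beyond the usual scatter. For the measured compounds named here, the only single-point step among the measured compounds is a 1.2-fold higher number from compound 2 to compound 3 (0.06 log units; within the scatter), a change on the sulfonyl sulfur that left the read-out essentially unmoved.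

Compound 4, `CCN(CC)S(=O)(=O)c1ccc(S(=O)(=O)N2CCC[C@@H](C(=O)N[C@H]3CCOC3)C2)cc1`, is not yet measured. It differs from compound 1 in one place: oxolan-3-yl in place of 4-methoxycyclohexyl on an amide-type nitrogen. Going by the values given here, no measured step touches the amide-type nitrogen, and compounds 2 and 3 differ from compound 1 at the sulfonyl sulfur as well as at the amide, so their values give no clean guide to this change. The data therefore offer nothing to predict a step beyond the scatter, and compound 4 is expected to come out close to compound 1, with no change at the digits printed from compound 1 to compound 4 (within the scatter) as the anticipated movement. The estimate for compound 4 in this assay is 2000 nM, within an expected range of 700 nM to 6000 nM.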

Compound 4, half-maximal inhibitory concentration: 5270 nM
Compound 4: the middle estimate sits 2.6-fold (0.42 log units) below what was measured; measured number inside the range.
By their numbers in this assay, from the lowest: compounds 2 and 3 (each within the scatter of the next); then compound 1; then compound 4.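

For the compounds shown here, the amide-type nitrogen, untouched by any earlier step, proves to be a place where the read-out moves: in this assay, oxolan-3-yl in place of 4-methoxycyclohexyl gives a 2.6-fold higher number from compound 1 to compound 4 (0.42 log units; beyond the scatter), whereas the only earlier step, at a sulfonyl sulfur, gave a 1.2-fold higher number from compound 2 to compound 3 (0.06 log units; within the scatter) and stayed within the scatter. The change is modest and runs towards weaker inhibition, and it comes with fewer heavy atoms, a five-membered ring in place of a six-membered one and one defined stereocentre fewer, while the counts of hydrogen-bond donors and acceptors stay the same. These differences arrive together in a single step, so it cannot be said which of them goes with the higher number, and no supporting evidence bears on the cause.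

The compounds shown leave open whether a plain cyclohexyl, a longer chain such as n-hexyl or a substituent carrying an amine on this nitrogen would lie closer to compound 1 or to compound 4. They also leave open whether the same exchange would move the number to a similar extent on a compound with isobutyl on the sulfonyl sulfur.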